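This account rests on a few compounds, and the source may have more. Where it says the series, first, only, none or still open, it means among the compounds named here.

For the measured compounds named here, in an ADME assay on isolated protein for inhibition of sodium-dependent dopamine transporter (Homo sapiens), tested at 10 uM (a higher number here means more inhibition at the concentration tested (going by the name of the read-out), a lower number less inhibition), compound 2 `Cc1cc(Cl)ccc1NC(=O)NCCCCC(c1ccc(F)cc1)c1ccc(F)cc1` gives 58%, the lower of the two numbers measured so far. Compound 1 `Cc1ccc(NC(=O)NCCCCC(c2ccc(F)cc2)c2ccc(F)cc2)cc1C` gives 79%, and the step of a number 21 percentage points lower from compound 1 to compound 2 (beyond the scatter) lies beyond the scatter. Compound 3 `O=C(NCCCCC(c1ccc(F)cc1)c1ccc(F)cc1)c1ccc(Cl)c(C(F)(F)F)c1` has not been measured; it differs from compound 2 by 4-chloro-3-(trifluoromethyl)phenyl in place of (4-chloro-2-methylphenyl)amino on a carbonyl carbon. Going by the values given here, the one measured step exchanges only the aryl group on the amide-type nitrogen and does not cover replacing an amino-bearing group by an aryl group on the carbonyl carbon, so no direction can be read from it. Compound 3 is therefore expected to give about 55%, estimated between 25% and 80%, an expected step of a number 3 percentage points lower from compound 2 to compound 3 (within the scatter).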

Compound 3, a percentage reported as inhibition, at one concentration (the size of the read-out at that concentration, not a potency): 51%
Compound 3: the middle estimate sits 4 percentage points above what was measured; the measured number falls inside the stated range.
By their numbers in this assay, from the lowest: compounds 3 and 2 (each within the scatter of the next); then compound 1.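

In this assay, the exchange on the carbonyl carbon gives a number 7 percentage points lower from compound 2 to compound 3 (within the scatter), so an aryl group with no hydrogen-bond donor can stand in place of the (4-chloro-2-methylphenyl)amino group without a step beyond the scatter. The corresponding exchange for (3,4-dimethylphenyl)amino gives a number 28 percentage points lower from compound 1 to compound 3 (beyond the scatter), so the size of the step depends on which amino group leaves. Nothing available explains either step. Going by these compounds, the amino nitrogen and the ring substituents change together here, and their separate contributions remain open. On these data alone, whether an unsubstituted phenyl on the carbonyl carbon or a shorter chain would keep the number also remains open.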